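From Cyano to Methylsulfanyl on the Aromatic Carbon

The compounds below may be only part of what the source reports. "The series", "measured", "known", "first", "only" and "open" are said of these compounds alone.

Compound 1 `N#Cc1ccccc1N1CCN(Cc2nc3ccccc3[nH]2)CC1` gives the highest of the three numbers in an assay on HEK293 cells with D(4) dopamine receptor (Homo sapiens) as the target, read by FLIPR (on this read-out higher numbers stand for larger maximal responses and lower numbers for smaller maximal responses), reaching 46%. Compound 3 `Fc1ccccc1N1CCN(Cc2nc3ccccc3[nH]2)CC1`, with fluoro in place of cyano, sits close at 42%, a move of a number 4 percentage points lower from compound 1 to compound 3 (within the scatter). Compound 2 `Fc1cccnc1N1CCN(Cc2nc3ccccc3[nH]2)CC1`, with 3-fluoropyridin-2-yl in place of 2-cyanophenyl, falls to 27%, a step of a number 19 percentage points lower from compound 1 to compound 2 (beyond the scatter), and a number 15 percentage points higher from compound 2 to compound 3 (beyond the scatter) separates it from compound 3. Compound 4 `CSc1ccccc1N1CCN(Cc2nc3ccccc3[nH]2)CC1` differs from compound 1 by methylsulfanyl in place of cyano on an aromatic carbon. Among the measured compounds shown here, the one step that bears on exchanging this group at this place is a number 4 percentage points lower from compound 1 to compound 3 (within the scatter), which stayed within the scatter. Compound 4 is therefore expected to show a number 3 percentage points lower from compound 1 to compound 4 (within the scatter), nothing beyond the scatter. The estimate for compound 4 in this assay is 43%, within 26% to 60%.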

Compound 4, largest response reached (reported as efficacy), in percent of the reference or control that the assay uses: 42%
Compound 4: middle estimate off by 1 percentage points, on the high side, within the range that was stated.
By their numbers in this assay, from the lowest: compound 2; then compounds 3, 4 and 1 (each within the scatter of the next).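

With a number 4 percentage points lower from compound 1 to compound 4 (within the scatter) and no change at the digits printed from compound 3 to compound 4 (within the scatter) methylsulfanyl joins fluoro as a second replacement for cyano on this aromatic carbon that leaves the number within the scatter. With a number 15 percentage points higher from compound 2 to compound 4 (beyond the scatter) compound 2 remains the only one of the four set apart, and it alone carries 3-fluoropyridin-2-yl rather than a substituted phenyl. The data at hand offer no explanation for either observation. As far as these compounds go, whether an amine, a carboxylic acid or a longer chain on this carbon would keep the number at this level stays open.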